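Swapping a sulfonamide for an amide on the shared core

This account rests on a few compounds, and the source may have more. Where it says the series, first, only, none or still open, it means among the compounds named here.

Compound 1, `CCCN(CCC)S(=O)(=O)c1ccc(S(=O)(=O)N2CCC[C@@H](C(=O)OCC)C2)cc1`: 2300 nM
Compound 2, `CCOC(=O)[C@@H]1CCCN(S(=O)(=O)c2ccc(S(=O)(=O)N3CCCCC3)cc2)C1`: 2900 nM
Compound 3, `CCOC(=O)[C@@H]1CCCN(S(=O)(=O)c2ccc(S(=O)(=O)N3CCNCC3)cc2)C1`: > 30000 nM

In a functional assay on MIA PaCa-2 cells (Homo sapiens) for inhibition, read by MTT assay, with a stated time of 7 days (a higher number here means a weaker inhibitor, a lower number a stronger inhibitor), compound 1 gives 2300 nM and compound 2 gives 2900 nM. Compound 3 gives only a limit, > 30000 nM, so its true value is not known beyond (the limit of > 30000 nM in this assay, at which 1 of the 3 values shown sits). Compound 3 therefore stands at the weak end of the three. The step of a 1.3-fold higher number from compound 1 to compound 2 (0.10 log units; within the scatter) is small, whereas an at least 13-fold higher number from compound 1 to compound 3 (1.11 log units; beyond the scatter) and an at least 10-fold higher number from compound 2 to compound 3 (1.01 log units; beyond the scatter) are both large losses.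

Compound 4, `CCOC(=O)[C@@H]1CCCN(S(=O)(=O)c2ccc(C(=O)N(CC)CC)cc2)C1`, differs from compound 3 in one place: diethylcarbamoyl in place of (piperazin-1-yl)sulfonyl on an aromatic carbon. The entering group, like dipropylamino in compound 1 and piperidin-1-yl in compound 2, carries 0 hydrogen-bond donors, and both measured steps that brought in the piperazin-1-yl group cost a great deal. Against that, no measured pair tests the change from a sulfonyl to a carbonyl link, so the size of the step is uncertain. Because of an at least 10-fold higher number from compound 2 to compound 3 (1.01 log units; beyond the scatter) and an at least 13-fold higher number from compound 1 to compound 3 (1.11 log units; beyond the scatter) a large gain, an at least 6.0-fold lower number from compound 3 to compound 4 (0.77 log units; beyond the scatter), is expected for compound 4. Compound 4 is estimated at 5000 nM, with a range from 1500 nM to 30000 nM.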

Compound 4, half-maximal inhibitory concentration: 800 nM
Compound 4: middle estimate off by 6.3-fold (0.80 log units), on the high side; measured number below the stated range.
By their numbers in this assay, from the lowest: compound 4; then compounds 1 and 2 (each within the scatter of the next). At a limit, above all of these: compound 3.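

Earlier, only the amine on a sulfonyl sulfur changed; compound 4 shows that this sulfonyl link on the aromatic carbon is not required for activity in this assay. Diethylcarbamoyl improves on both earlier groups by more than the scatter, though modestly, with a 3.6-fold lower number from compound 2 to compound 4 (0.56 log units; beyond the scatter) and a 2.9-fold lower number from compound 1 to compound 4 (0.46 log units; beyond the scatter). The larger step, an at least 37-fold lower number from compound 3 to compound 4 (1.57 log units; beyond the scatter), can only be read as a minimum, as compound 3 gives a limit and not a true number: the limit of > 30000 nM in this assay, at which 1 of the 4 values shown sits.

The change in compound 4 replaces the link and the amine part together, so the gain cannot yet be assigned to the carbonyl or to the two ethyl groups. A diethylsulfamoyl group or a piperidin-1-ylcarbonyl group on the same aromatic carbon would separate the two, since each changes only one of them.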